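The source may hold more compounds than are shown below. What is called first, only, known or untested is meant among the compounds shown, and "the series" means these compounds.

Measured so far:

compound 1, `COc1ccc(/C=C/c2cc(=O)cco2)cc1` — 379 uM
compound 2, `COc1ccc(/C=C/c2cc(=O)cco2)cc1OC` — 807 uM
compound 3, `COc1ccc(/C=C/C2CC=CC(=O)N2)cc1` — > 1090 uM

Of the compounds shown here, three have been tested in a functional assay on HT-29 cells (Homo sapiens) for inhibition, read by sulforhodamine B assay, with a stated time of 48 h; on this read-out higher numbers stand for weaker inhibition of growth and lower numbers for stronger inhibition of growth. Compound 1 gives 379 uM in this assay. Compound 2 differs from compound 1 by one change, (methoxy in place of hydrogen on an aromatic carbon), and in this assay compound 2 gives 807 uM. That change produced a 2.1-fold higher number from compound 1 to compound 2 (0.33 log units; beyond the scatter), so adding the methoxy group made the growth inhibition weaker. Compound 3 carries a different core, and the difference between the two cores is not broken down here. For compound 3 this assay reports only a limit, > 1090 uM, not a number. This is the limit of > 1090 uM in this assay, at which 1 of the 3 values shown sits.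

Compound 4, `COc1ccc(/C=C/C2CC=CC(=O)N2)cc1OC`, has not yet been measured. It stands to compound 3 as compound 2 stands to compound 1: the change is methoxy in place of hydrogen on an aromatic carbon, and its place line reads the same word for word as the earlier one, so it is the same change. On the earlier core that change weakened inhibition, and compound 3 already sits at the limit of the assay, so compound 4 is expected to show weak inhibition as well, with an estimated step that the limit leaves unreadable from compound 3 to compound 4. The estimate for compound 4 in this assay is 2200 uM, with a likely span from 1000 uM to 5000 uM, and most probably the assay will again report only a limit.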

Compound 4, concentration for growth inhibition (reported as GI): > 964 uM
Compound 4 gave a limit, no number; the forecaster's own chance of this, stated with the estimate: 85%; the middle value lies beyond the limit too.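

In this assay compound 3 gives only a limit, > 1090 uM. Compound 4 also gives only a limit, > 964 uM. No size can be read for the step between compound 3 and compound 4, so nothing new can be said about this change. The compounds shown leave open whether methoxy in place of hydrogen on an aromatic carbon weakens growth inhibition on the core of compound 3, as it does on the core of compound 1.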